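From benzyl to 4-methylbenzyl on compound 2

The source may hold more compounds than are shown below. What is called first, only, known or untested is meant among the compounds shown, and "the series" means these compounds.

Compound 1 `COc1ccc(Cc2nnc(NC(=O)/C(C#N)=C/c3ccccc3OS(=O)(=O)c3ccc([N+](=O)[O-])cc3)s2)cc1` reads 3670 nM
Compound 2 `COc1ccc(S(=O)(=O)Oc2ccccc2/C=C(\C#N)C(=O)Nc2nnc(Cc3ccccc3)s2)cc1` reads 1060 nM

In a functional assay on RS4-11 cells (Homo sapiens) for inhibition, read by CCK-8 assay, with a stated time of 48 h (on this read-out higher numbers stand for weaker inhibition and lower numbers for stronger inhibition), compound 2 stands lowest of the two at 1060 nM and compound 1 lies higher at 3670 nM by a gap beyond the usual scatter. Compound 3 `COc1ccc(S(=O)(=O)Oc2ccccc2/C=C(\C#N)C(=O)Nc2nnc(Cc3ccc(C)cc3)s2)cc1` carries one change from compound 2: methyl in place of hydrogen on an aromatic carbon with methyl in place of hydrogen on an aromatic carbon, para to a large group. Among the compounds with values here, no measured pair shows this change, so the expectation starts from compound 2 at 1060 nM and assumes little movement. The expected 1.1-fold lower number from compound 2 to compound 3 (0.03 log units; within the scatter) is none beyond the scatter in this assay in either direction. Compound 3 is therefore estimated at 1000 nM with an expected range from 400 nM to 2500 nM on this read-out.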

Compound 3, half-maximal inhibitory concentration: 1010 nM
Compound 3: middle estimate off by 1.0-fold (0.00 log units), on the low side, and the stated range covers the measured number.
By their numbers in this assay, from the lowest: compounds 3 and 2 (each within the scatter of the next); then compound 1.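

In this assay the change from benzyl to 4-methylbenzyl gives a 1.0-fold lower number from compound 2 to compound 3 (0.02 log units; within the scatter) and so leaves the reading unmoved beyond the scatter. This aromatic carbon, para to a large group, therefore accepts a methyl in place of hydrogen with no change that can be told from the scatter. Nothing at hand explains this outcome.

Methyl is the only group shown on this carbon, so it remains open how an amine, a carboxylic acid or a longer chain would read there. From the compounds shown here alone, whether the same methyl would behave alike on another carbon of this ring also stays open.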